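The source may hold more compounds than are shown below. What is called first, only, known or untested is meant among the compounds shown, and "the series" means these compounds.

Compound 1 `COc1ccc(N2C(=O)COc3ccc(-c4cnc(OC)c(NS(=O)(=O)c5ccc(F)cc5)c4)cc32)cc1` gives 18400 nM in a functional assay on A-375 cells (Homo sapiens) for antiproliferative activity, read by MTT assay, with a stated time of 72 h; on this read-out lower numbers stand for stronger inhibition and higher numbers for weaker inhibition. Compound 2 `O=C1COc2ccc(-c3cccc(NS(=O)(=O)c4ccc(F)cc4)c3)cc2N1c1ccc(Cl)cc1` gives 32500 nM and compound 3 `COc1ccc(N2C(=O)COc3ccc(-c4cnc(Cl)c(NS(=O)(=O)c5ccc(F)cc5)c4)cc32)cc1` gives 32700 nM in this assay, both within the scatter of compound 1, so no order among the three can be read. Among the compounds with values here, the only single-point step available, a 1.8-fold higher number from compound 1 to compound 3 (0.25 log units; within the scatter), concerns a different methoxy group and was itself within the scatter. Compound 4 `COc1ncc(-c2ccc3c(c2)N(c2ccccc2)C(=O)CO3)cc1NS(=O)(=O)c1ccc(F)cc1` differs from compound 1 by hydrogen in place of methoxy on an aromatic carbon. Within the data shown here, no measured step bears directly on this change; the one step in hand suggests that removing or swapping a methoxy leaves the number within the scatter. Compound 4 is therefore expected at 20000 nM, with a range of 8000 nM to 50000 nM, an estimated step of a 1.1-fold higher number from compound 1 to compound 4 (0.04 log units; within the scatter).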

Compound 4, half-maximal inhibitory concentration: 15200 nM
For compound 4 the middle estimate is 1.3-fold (0.12 log units) above the measured one; measured number inside the range.
By their numbers in this assay, from the lowest: compounds 4, 1, 2 and 3 (each within the scatter of the next, the first and the last beyond it).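

In this assay, the change from 4-methoxyphenyl to phenyl gives a 1.2-fold lower number from compound 1 to compound 4 (0.08 log units; within the scatter), so on this evidence the methoxy at this place, para to a large group, can be replaced by hydrogen with no readable shift in the number. Within the data shown here, this is the only step at this position, since the earlier step concerned the other methoxy group. No measured evidence bears on this result.

From the compounds shown here alone, whether an amine, a carboxylic acid or a longer alkoxy chain at this place would move the number beyond the scatter stays open. Also open, going by these compounds, is whether any group here would separate from compound 4 at all.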